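Trimming the chain at the indole ring

A few compounds are considered here, and "the series" means these few. Any claim that something is new, unique, unknown or untested is made for them only; others in the source may bear on it.

Compound 1 `COc1cccc(-c2[nH]c3ccc(OC)cc3c2C2=C(Br)C(=O)NC2=O)c1`: 2.79
Compound 2 `CCCCCCOc1ccc2[nH]c(-c3cccc(OC)c3)c(C3=C(Br)C(=O)NC3=O)c2c1`: 3.92

In a physicochemical assay for lipophilicity (on this read-out higher numbers stand for higher lipophilicity and lower numbers for lower lipophilicity), compound 2 stands highest of the two measured compounds. Within the data shown here, the single measured step, a number 1.13 log units higher from compound 1 to compound 2 (beyond the scatter), shows how much a longer chain on the oxygen raises this read-out. Compound 3 `CCc1ccc2[nH]c(-c3cccc(OC)c3)c(C3=C(Br)C(=O)NC3=O)c2c1` goes the other way: ethyl in place of hexyloxy on an aromatic carbon. A shorter group with no oxygen is expected to pull the number down, though less than the full length of chain removed would suggest, since ethyl lacks the oxygen. The estimate for compound 3 is 3.3, between 2.8 and 3.8, a step of a number 0.62 log units lower from compound 2 to compound 3 (beyond the scatter).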

Compound 3, partition coefficient: 3.35
Compound 3: the middle estimate sits 0.05 log units below what was measured; low and high end bracket the measured number.
By their numbers in this assay, from the lowest: compound 1; then compound 3; then compound 2.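

In this assay, the step to ethyl is a number 0.57 log units lower from compound 2 to compound 3 (beyond the scatter), and the step from the short methoxy is a number 0.56 log units higher from compound 1 to compound 3 (beyond the scatter). These two steps are about equal in size, so a small group without an oxygen on this aromatic carbon places compound 3 about midway between compound 1 and compound 2. No measurement shown here explains this order.

Ethyl differs from both methoxy and hexyloxy in chain and in oxygen at once, so the part played by the oxygen alone remains open. A hexyl chain joined directly to this carbon could separate the two, while an amine here would test a different kind of group.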